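This account rests on a few compounds, and the source may have more. Where it says the series, first, only, none or still open, it means among the compounds named here.

Compound 2 `C=C(Br)C(=O)Nc1cccc(-c2cn3nc(-c4ccc(F)cc4)sc3n2)c1` is the anchor of this account. Among the compounds with values here, in a functional assay on FM3A cells (Mus musculus) for inhibition, read by cell counting, with a stated time of 2 days (a lower number here means a stronger inhibitor, a higher number a weaker inhibitor), compound 2 gives 610 nM, the only number in the set. The second compound shown, compound 1 `Nc1cccc(-c2cn3nc(-c4cccs4)sc3n2)c1`, is recorded only as a limit of this assay, > 250000 nM, and the limit of > 250000 nM in this assay, at which 1 of the 2 values shown sits, marks it as such, so it offers no point of comparison beyond showing that compound 1 did not reach measurable inhibition within the range tested. Within the data shown here, compound 2 thus stands alone as the single measured value.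

The step leads to compound 3 `C=C(Br)C(=O)Nc1cccc(-c2cn3nc(-c4ccc(OCC)cc4)sc3n2)c1`, which differs from compound 2 by a single change: ethoxy in place of fluoro on an aromatic carbon. The bromoacrylamide and the shared core are left untouched.

Among the measured compounds shown here, no measured step of this kind is available in the set, so the size of the change in this assay can only be anticipated. The change is small in the count of atoms and sits on the distal phenyl ring, and the expectation is for a step of a 1.0-fold lower number from compound 2 to compound 3 (0.01 log units; within the scatter) that stays within the usual scatter, with no clear direction. Compound 3 is therefore estimated at 600 nM, with a likely range from 150 nM to 2500 nM.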

Compound 3, half-maximal inhibitory concentration: 1100 nM
For compound 3 the middle estimate is 1.8-fold (0.26 log units) below the measured one; measured number inside the range.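

Within the data shown here, compound 3 gives the first measured step at this place on the distal ring, and in this assay that step is a 1.8-fold higher number from compound 2 to compound 3 (0.26 log units; within the scatter), so the two compounds are not told apart by this read-out. On an aromatic carbon para to a large group, the 4-fluorophenyl of compound 2 can therefore give way to the 4-ethoxyphenyl of compound 3, with one fluorine replaced by two carbons and an oxygen, while inhibition of the FM3A cells stays measurable and no shift beyond the scatter appears. Among these compounds, the one limit among the values shown does not bear on this pair, and nothing at hand gives a reason for the size of this step.

This single pair, both members carrying the bromoacrylamide, cannot show whether the same tolerance would hold for an amine, a carboxylic acid or a longer chain such as butoxy at this place. It also leaves open whether a hydroxy group or a methoxy group there would stay as close to compound 2, and whether ethoxy would behave the same way on a core without the bromoacrylamide.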